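Thiophene for phenyl across two ring sizes, plasma assay

The source may hold more compounds than are shown below. What is called first, only, known or untested is meant among the compounds shown, and "the series" means these compounds.

Measured compounds:
compound 1 `c1ccc(C(/N=C2\CCCCCN2)C2CC2)cc1`: 5%
compound 2 `c1ccc(C(/N=C2\CCCCCCN2)C2CC2)cc1`: 0%
compound 3 `c1csc(C(/N=C2\CCCCCN2)C2CC2)c1`: 33%

In a functional assay on the whole organism (plasma, strain Sprague-Dawley) with Rattus norvegicus as the target, with a stated time of 2 h, at a dose of 12.5 mg/kg by the oral route (a higher number here means a stronger effect of the compound at the dose given, a lower number a weaker effect), compound 1 gives 5% and compound 3 gives 33%. The change between them is thiophen-2-yl in place of phenyl on a saturated chain carbon bound to a double-bonded nitrogen and a saturated ring carbon; it made a step of a number 28 percentage points higher from compound 1 to compound 3 (beyond the scatter). Compound 2 gives 0% in this assay; compound 2 and compound 1 lie within the scatter of each other, while compound 3 stands beyond the scatter above compound 2. The difference between the core of compound 1 and the core of compound 2 is not broken down here.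

Compound 4 `c1csc(C(/N=C2\CCCCCCN2)C2CC2)c1` is not yet measured. Its change from compound 2 is thiophen-2-yl in place of phenyl on a saturated chain carbon bound to a double-bonded nitrogen and a saturated ring carbon, the same change, at the same place, as from compound 1 to compound 3. Among the compounds shown this change occurs twice. For the measured compounds named here, the step from compound 2 is expected to be a number 25 percentage points higher from compound 2 to compound 4 (beyond the scatter), which rests on the single earlier step of a number 28 percentage points higher from compound 1 to compound 3 (beyond the scatter); with only one precedent the expectation is loosely held. Compound 4 is therefore estimated at 25% in this assay, expected to fall between 5% and 45%.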

Compound 4, a percentage reported as inhibition, in the whole organism at one dose (the size of the read-out at that dose, not a potency): 17%
Compound 4: the middle estimate sits 8 percentage points above what was measured; measured number inside the range.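

In this assay, the thiophen-2-yl change again gives a higher read-out on the second core, with a number 17 percentage points higher from compound 2 to compound 4 (beyond the scatter). Set beside the earlier step, the two do not separate: the same change on two cores in this assay, a number 28 percentage points higher (beyond the scatter) from compound 1 to compound 3 and a number 17 percentage points higher (beyond the scatter) from compound 2 to compound 4, 11 percentage points apart, within the scatter of two such steps

For the compounds shown here, the change therefore carries over between these two cores in direction and, within the scatter, in size, but this rests on only two matched pairs at a single oral dose and time point, so it shows neither a potency nor a reason for the effect.

The compounds shown leave open whether the step holds on any further core, and they do not break down the difference between the core of compound 1 and the core of compound 2. Also open, going by these compounds, is how the read-out would respond to an amine or a carboxylic acid on the thiophen-2-yl group, or to a longer chain on the saturated chain carbon bound to the double-bonded nitrogen.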